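The compounds below may be only part of what the source reports. "The series", "measured", "known", "first", "only" and "open" are said of these compounds alone.

In an ADME assay on HEL cells (Homo sapiens), read by cell counting, with a stated time of 3 days (on this read-out lower numbers stand for higher toxicity in this test and higher numbers for lower toxicity in this test), compound 1 (`O=c1[nH]c(=O)n([C@H]2C[C@H](O)[C@@H](CO)O2)cc1C#CC#Cc1ccccc1`) gives 100000 nM and compound 3 (`O=c1[nH]c(=O)n([C@H]2C[C@H](O)[C@@H](CO)O2)cc1C#CC#Cc1ccccn1`) gives 1500 nM while compound 2 (`CCCCCCc1ccc(C#CC#Cc2cn([C@H]3C[C@H](O)[C@@H](CO)O3)c(=O)[nH]c2=O)cc1`) stands second highest of the three numbers at 35000 nM (apart from both others by more than the scatter). Compound 4 (`Nc1ccc(C#CC#Cc2cn([C@H]3C[C@H](O)[C@@H](CO)O3)c(=O)[nH]c2=O)cc1`) departs from compound 2 in one place: amino in place of hexyl on an aromatic carbon. For the measured compounds named here, two measured steps bear on this change. The step with hexyl in place of hydrogen on an aromatic carbon is modest (a 2.9-fold lower number from compound 1 to compound 2 (0.46 log units; beyond the scatter)) and suggests that the hexyl group does not by itself move the number far. The step with pyridin-2-yl in place of phenyl is large (a 67-fold lower number from compound 1 to compound 3 (1.82 log units; beyond the scatter)) and shows that a change in this aromatic group can lower the number strongly. Going by the values given here, no measured compound carries amino, so both steps guide the expectation only loosely. The expected change in this assay is a modest step toward a lower number (a 2.3-fold lower number from compound 2 to compound 4 (0.37 log units; beyond the scatter)). For compound 4 the estimated value is 15000 nM (expected range 2500 nM to 90000 nM).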

Compound 4, half-maximal cytotoxic concentration in the HEL assay: > 100000 nM
Compound 4 gave a limit, no number; the forecaster's own chance of this, stated with the estimate: 15%; middle value at least 6.6-fold (0.82 log units) away from the limit.
By their numbers in the HEL assay, from the lowest: compound 3; then compound 2; then compound 1.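

In the HEL assay, amino in place of hexyl on an aromatic carbon, para to a large group, raises the number: an at least 2.8-fold higher number from compound 2 to compound 4 (0.45 log units; beyond the scatter), and the change of aromatic group gives an at least 66-fold higher number from compound 3 to compound 4 (1.82 log units; beyond the scatter). Compound 4 gives > 100000 nM, which is a limit and not a number. In the HEL assay the step from compound 1 is a number no lower from compound 1 to compound 4 (the limit leaves the size open), and its size cannot be read. In a physicochemical assay for lipophilicity (on this read-out lower numbers stand for lower lipophilicity and higher numbers for higher lipophilicity), compound 2 gives 3.7 and compound 4 gives 0.13. In this one pair, the higher number in the HEL assay goes with a lower partition coefficient in the physicochemical assay, a number 3.57 log units lower from compound 2 to compound 4 (beyond the scatter): the measured partition coefficient of compound 2, 3.7, and of compound 4, 0.13, a number 3.57 log units lower (beyond the scatter)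

This single pair does not separate the loss of the hexyl chain from the arrival of amino. Going by these compounds, it remains open where a butyl chain or a dimethylamino group at this same place would fall in the HEL assay, and whether the link to the partition coefficient would hold for them.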